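The compounds below may be only part of what the source reports. "The series", "measured", "known", "first", "only" and "open" are said of these compounds alone.

For the measured compounds named here, in a functional assay on L1210 cells (Mus musculus) for inhibition, read by cell counting, with a stated time of 2 days (on this read-out lower numbers stand for stronger inhibition and higher numbers for weaker inhibition), compound 1 `C=C(Br)C(=O)Nc1cccc(-c2cn3nc(-c4ccc(OC)c(OC)c4)sc3n2)c1` gives 42 nM, the only value in this set that is a number rather than a limit. Compound 2 `COc1cccc(-c2nn3cc(-c4cccc(N)c4)nc3s2)c1` returns only a limit of the assay, > 250000 nM. Compound 3 `Nc1cccc(-c2cn3nc(-c4ccc(F)cc4)sc3n2)c1` likewise reaches only a limit of the assay, >= 250000 nM. Compound 4 `C=C(Br)C(=O)Nc1cccc(-c2cn3nc(Cc4ccc(OC)cc4)sc3n2)c1` has not yet been measured in this assay. The change from compound 1 to compound 4 is 4-methoxybenzyl in place of 3,4-dimethoxyphenyl on an aromatic carbon. Going by the values given here, no step between two measured compounds is available here to set beside this change, so the size of its effect on inhibition stays open. A moderate weakening, somewhat beyond the usual scatter, is expected, a 3.6-fold higher number from compound 1 to compound 4 (0.55 log units; beyond the scatter). Compound 4 is therefore estimated at 150 nM, with a range from 30 nM to 800 nM.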

Compound 4, half-maximal inhibitory concentration: 1400 nM
The estimate for compound 4 lay 9.3-fold (0.97 log units) below the measured number; the measured number lies above the stated range.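

Putting 4-methoxybenzyl in place of 3,4-dimethoxyphenyl gives a 33-fold higher number from compound 1 to compound 4 (1.52 log units; beyond the scatter) in this assay, so inhibition depends strongly on the group at this aromatic carbon. For the compounds shown here, compound 4 still gives a measured number rather than a limit, which makes this the first change here whose size can be read. Nothing measured here explains the size of this step.

The swap alters both the group's link to the core and its methoxy pattern, so these two changes cannot be separated. A 4-methoxyphenyl or 3,4-dimethoxybenzyl group at this position would pull them apart.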